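Removing One Chlorine from the Core of Compound 1

A few compounds are considered here, and "the series" means these few. Any claim that something is new, unique, unknown or untested is made for them only; others in the source may bear on it.

Of the compounds shown here, three have been measured in a functional assay on MDA-MB-435 cells (Homo sapiens) for cytotoxicity, read by sulforhodamine B assay, with a stated time of 48 h; a higher number here means that more compound is tolerated, a lower number that less compound is tolerated. Compound 1 `ClCc1cccc(Cn2cnc3c(Cl)nc(Cl)nc32)c1` gives 6310 nM in this assay, the lowest of the three numbers. Compound 3 `ClCc1ccccc1Cn1cnc2ncnc(Cl)c21` gives 7580 nM in this assay, a number that lies within the usual scatter of that of compound 1, so no order between the two can be read. Compound 2 `ClCc1ccc(Cn2cnc3c(Cl)nc(Cl)nc32)cc1` gives 50100 nM in this assay, which stands well beyond the scatter above compound 1.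

Compound 4 `ClCc1cccc(Cn2cnc3c(Cl)ncnc32)c1` has not yet been measured. It differs from compound 1 in one place: hydrogen in place of chloro on an aromatic carbon. Compound 3 also carries a single chloro group on its core and comes out close to compound 1, which gives no sign that such a change moves the number far. The step from compound 1 to compound 4 is therefore expected to be small, in either direction, and likely within the scatter: a 1.3-fold higher number from compound 1 to compound 4 (0.10 log units; within the scatter). For compound 4 the estimated value in this assay is 8000 nM, with a range from 3000 nM to 25000 nM.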

Compound 4, concentration lethal to 50% of the cells: 6450 nM
Beside the measured number, compound 4's estimate is 1.2-fold (0.09 log units) above it; measured number inside the range.
By their numbers in this assay, from the lowest: compounds 1, 4 and 3 (each within the scatter of the next); then compound 2.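

In this assay, putting hydrogen in place of the chloro group on the aromatic carbon between two ring nitrogen atoms gives a 1.0-fold higher number from compound 1 to compound 4 (0.01 log units; within the scatter), so the two compounds cannot be told apart here. This is the first pair shown that differs in one place only, and it isolates this position in a way the earlier compounds could not. On this core, which keeps its other chloro group, a chloro group at this position is not needed for a number of this size. Nothing at hand speaks to the reason for this.

Going by these compounds, how this position responds to a group other than chloro or hydrogen, such as an amine, a methoxy group or a longer chain, remains open. So does whether removing the remaining chloro group from the core would leave the number just as close.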